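Replacing 3,4-Difluorophenyl with 4-Aminophenyl in Compound 3

The source may report more compounds than this note shows. Statements on the series, on what has been measured and on what is new or still open speak of the compounds shown alone.

Of the compounds shown here, two sharing one core have been measured. Compound 1 `C#CCOc1cccc(/C=C/C(=O)Nc2cc(C(=O)c3cc(OC)c(OC)c(OC)c3)ccc2OC)c1` carries a 3-(propargyloxy)phenyl group on the double-bonded chain carbon, and in a functional assay on B16 cells (Mus musculus) for cytotoxicity, read by MTT assay, with a stated time of 72 h (on this read-out lower numbers stand for stronger inhibition and higher numbers for weaker inhibition), compound 1 gives 12200 nM. Compound 2 `COc1ccc(C(=O)c2cc(OC)c(OC)c(OC)c2)cc1NC(=O)/C=C/c1ccc(F)c(F)c1` bears a 3,4-difluorophenyl group at that same place, and in this assay compound 2 gives 6500 nM. The step of a 1.9-fold lower number from compound 1 to compound 2 (0.27 log units; within the scatter) lies within the usual scatter, so the two numbers cannot be told apart, and compound 2 simply stands alongside compound 1 on the data shown.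

Compound 3 `COc1ccc(C(=O)c2cc(OC)c(OC)c(OC)c2)cc1NC(=O)/C=C/c1ccc(N)cc1` has not yet been measured. It differs from compound 2 in one place: 4-aminophenyl in place of 3,4-difluorophenyl on a double-bonded chain carbon bound to a double-bonded chain carbon. Within the data shown here, no measured step speaks to this particular exchange, since the only comparison available, a 1.9-fold lower number from compound 1 to compound 2 (0.27 log units; within the scatter), concerns a different pair of groups and itself stays within the scatter. With nothing to point in either direction, compound 3 is expected to sit near compound 2, with a step of a 1.1-fold lower number from compound 2 to compound 3 (0.03 log units; within the scatter) that does not rise above the scatter. Compound 3 is therefore estimated at 6000 nM, with a range from 1500 nM to 25000 nM.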

Compound 3, half-maximal inhibitory concentration: 7900 nM
The estimate for compound 3 lay 1.3-fold (0.12 log units) below the measured number, within the range that was stated.
By their numbers in this assay, from the lowest: compounds 2, 3 and 1 (each within the scatter of the next).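

In this assay, 4-aminophenyl in place of 3,4-difluorophenyl on a double-bonded chain carbon bound to a double-bonded chain carbon gives a 1.2-fold higher number from compound 2 to compound 3 (0.08 log units; within the scatter) and stays within the scatter, while 4-aminophenyl in place of 3-(propargyloxy)phenyl gives a 1.5-fold lower number from compound 1 to compound 3 (0.19 log units; within the scatter) and also stays within it. Among these compounds, the earlier pair offered a single step between two groups, whereas this place now holds three groups, and the one that enters brings a hydrogen-bond donor and a hydrogen-bond acceptor where 3,4-difluorophenyl has neither, with no step among compound 1, compound 2 and compound 3 rising above the scatter. The data offer nothing that would explain this result.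

What the three compounds leave open is whether any group at this place can move the number beyond the scatter, since all of them carry a substituted phenyl ring on the chain. A carboxylic acid or a dimethylamino group on that ring, or a longer chain ending in an amine, could test this, and the shared core remains untouched by these exchanges.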